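Chloro for fluoro on the benzyl ring of a triazole amide

The source may hold more compounds than are shown below. What is called first, only, known or untested is meant among the compounds shown, and "the series" means these compounds.

For the measured compounds named here, compound 1 `O=C(NCc1cn(Cc2ccc(Cl)cc2)nn1)c1cn(-c2ccccc2)nc1-c1ccccc1` is measured in a functional assay on MCF7 cells (Homo sapiens) for antiproliferative activity, read by sulforhodamine B assay, with a stated time of 48 h (a higher number here means a weaker inhibitor of growth, a lower number a stronger inhibitor of growth), as a limit, > 100000 nM, and it is the one value of the two that sits at the limit of > 100000 nM in this assay, at which 1 of the 2 values shown sits. Going by the values given here, compound 2 `O=C(NCc1cn(Cc2ccc(F)cc2)nn1)c1cn(-c2ccccc2)nc1-c1ccc(F)cc1` gives 55300 nM in this assay, the only number among the values shown. Compound 3 `O=C(NCc1cn(Cc2ccc(Cl)cc2)nn1)c1cn(-c2ccccc2)nc1-c1ccc(F)cc1` has not yet been measured. It differs from compound 2 by chloro in place of fluoro on an aromatic carbon. Among the compounds with values here, no step between two measured compounds is available, so nothing measured speaks to the size of this change. The expectation for compound 3 is therefore a step of a 1.1-fold higher number from compound 2 to compound 3 (0.04 log units; within the scatter) that stays within the scatter. Compound 3 is estimated at 60000 nM in this assay, with a range from 25000 nM to 150000 nM.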

Compound 3, concentration for 50% growth inhibition: 130 nM
For compound 3 the middle estimate is 460-fold (2.66 log units) above the measured one, and the stated range ends above it.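

In this assay, the change from 4-fluorobenzyl to 4-chlorobenzyl, on an aromatic carbon para to a large group, gives a 430-fold lower number from compound 2 to compound 3 (2.63 log units; beyond the scatter), so growth inhibition in this series depends strongly on which halogen sits at this position. With 4-chlorobenzyl held constant, a second place also matters: fluoro in place of hydrogen on an aromatic carbon gives an at least 760-fold lower number from compound 1 to compound 3 (2.88 log units; beyond the scatter). That second step starts from a limit rather than a number: the limit of > 100000 nM in this assay, at which 1 of the 3 values shown sits.

Bromo, methyl or methoxy in place of chloro on the benzyl ring would show whether the large step belongs to chloro alone. Compound 1 and compound 2 differ in two places, so the data leave open how the two changes combine beyond what compound 3 shows.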